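From 4-methoxybenzyl to 4-bromobenzyl

The source may hold more compounds than are shown below. What is called first, only, known or untested is meant among the compounds shown, and "the series" means these compounds.

In a functional assay on MCF7 cells (Homo sapiens) for inhibition, read by MTT assay, with a stated time of 48 h, tested at 10 uM (a lower number here means less inhibition of growth, a higher number more inhibition of growth at the concentration tested), compound 1 (`Cc1cc(=O)c2c(O)cc(OCc3ccccc3)c([C@H]3CCN(C)C[C@H]3O)c2o1`) gives 1%, while compound 2 (`COc1ccc(COc2cc(O)c3c(=O)cc(C)oc3c2[C@H]2CCN(C)C[C@H]2O)cc1`) gives 16%, the higher of the two numbers. Compound 3 (`Cc1cc(=O)c2c(O)cc(OCc3ccc(Br)cc3)c([C@H]3CCN(C)C[C@H]3O)c2o1`) has bromo in place of methoxy on an aromatic carbon, para to a large group: bromo in place of methoxy on an aromatic carbon. Among the compounds with values here, no measured compound carries bromo, and the only step bearing on this site is a number 15 percentage points higher from compound 1 to compound 2 (beyond the scatter), a modest one with methoxy in place of hydrogen on an aromatic carbon. A change no larger than that, in no clear direction, is expected in this assay. The estimated change is a number 2 percentage points higher from compound 2 to compound 3 (within the scatter). For compound 3 the expected value is 18%, with an estimated range of 3% to 38%.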

Compound 3, percent growth inhibition at one concentration: 14%
Beside the measured number, compound 3's estimate is 4 percentage points above it, and the stated range covers the measured number.
By their numbers in this assay, from the lowest: compound 1; then compounds 3 and 2 (each within the scatter of the next).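

In this assay, bromo in place of methoxy gives a number 2 percentage points lower from compound 2 to compound 3 (within the scatter), so the 4-bromobenzyl and 4-methoxybenzyl compounds cannot be told apart here. Bromo in place of hydrogen gives a number 13 percentage points higher from compound 1 to compound 3 (beyond the scatter), so the rise first seen with methoxy is not confined to that one group. Nothing available explains why these two groups read alike. Going by these compounds, what remains open is whether an amine or a carboxylic acid on this aromatic carbon would give a similar number. On these data alone, it also remains open whether a longer chain there would do so.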